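The compounds below may be only part of what the source reports. "The series", "measured", "known", "first", "only" and "open" are said of these compounds alone.

In a toxicity assay on cells (Erythrocyte, Homo sapiens) for cytotoxicity, read by hemolysis (a higher number here means that more compound is needed for the effect, a lower number that less compound is needed), compound 2 `CCCCCCCCCCCCCC(=O)NCc1ccc(C(=O)NCC(=O)O)cc1` stands only at a limit, > 50 ug/mL, and not at a number. Compound 1 `CCCCCCCCCCCCCC(=O)NCc1ccc(C(=O)N[C@@H](CC(N)=O)C(=O)O)cc1` is likewise known only by a limit, > 10 ug/mL. Among the compounds with values here, the one measured step is a step that the two limits leave unreadable from compound 1 to compound 2, so it offers no size to carry forward and leaves compound 2 without a firm starting value. Compound 3 `CCCCCCCCCCCCCC(=O)NCc1ccc(C(=O)N[C@H](C(N)=O)[C@@H](C)CC)cc1` carries 1-carbamoyl-2-methylbutyl in place of carboxymethyl on an amide-type nitrogen, and the counted difference is 1-carbamoyl-2-methylbutyl in place of carboxymethyl on an amide-type nitrogen. Within the data shown here, no measured step covers this change, so the expectation rests on the structural change alone and is held loosely. The expected move in this assay is an at least 1.6-fold lower number from compound 2 to compound 3 (0.22 log units; that floor lies within the scatter), an estimated shift toward less compound being needed. For compound 3 the estimated value is 30 ug/mL, with an expected range from 8 ug/mL to 100 ug/mL.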

Compound 3, half-maximal effective concentration: 100 ug/mL
For compound 3 the middle estimate is 3.3-fold (0.52 log units) below the measured one, and the stated range covers the measured number.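

Compound 1 and compound 2 stand only at limits in this assay, and the steps from each of them to compound 3 cannot be read. The compounds shown leave open in which direction, and how far, 1-carbamoyl-2-methylbutyl in place of carboxymethyl on an amide-type nitrogen moves the number.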